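Trading a methyl for a carboxyphenyl on the shared core

The source may hold more compounds than are shown below. What is called first, only, known or untested is meant among the compounds shown, and "the series" means these compounds.

Of the compounds shown here, two built on the same core have been tested in an ADME assay on S9 fraction from liver (Rattus norvegicus) for metabolic stability, read by LC-MS, using NADPH, with a stated time of 30 min; a lower number here means that less of the compound is left, a higher number that more of the compound is left. Compound 2 `CCCCCCCCc1ccc(OCC(=O)Cn2nnnc2C)cc1` gives 32%, the highest of the two numbers shown. Compound 1 `CCCCCCCCc1ccc(OCC(=O)Cn2nnc(-c3cccc(C(=O)OC)c3)n2)cc1` gives 19% in this assay, a gap that lies beyond the usual scatter, so compound 2 stands clearly above compound 1 on what has been measured so far.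

Compound 3 `CCCCCCCCc1ccc(OCC(=O)Cn2nnnc2-c2cccc(C(=O)O)c2)cc1` has not yet been measured. It differs from compound 2 in one place: 3-carboxyphenyl in place of methyl on an aromatic carbon.

Among the measured compounds shown here, no step between two measured compounds covers this particular change, so any expectation has to rest on the values themselves. Compound 1, which also bears an aryl group on its five-membered ring, gives 19%, a lower number than compound 2. On that basis a modest downward step is expected, a number 6 percentage points lower from compound 2 to compound 3 (within the scatter), though the direction is uncertain and a result within the scatter of compound 2 would not surprise. Compound 3 is estimated at 26%, with a range from 12% to 48%.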

Compound 3, percent of the compound remaining: < 5%
Compound 3: a limit, no number (the forecaster's own chance of this, stated with the estimate: 2%); middle value at least 21 percentage points from the limit.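

On the aromatic carbon of the five-membered ring, the place between two ring nitrogen atoms, the size of the group matters for what is left of the compound: with 3-carboxyphenyl in place of methyl, this assay shows a number at least 27 percentage points lower from compound 2 to compound 3 (beyond the scatter). Compound 3 stands at a limit of the assay and not at a number: the limit of < 5% in this assay, at which 1 of the 3 values shown sits. The step is therefore a lower bound on the change, and this pair, the only measured one differing in a single place, shows that this position on the shared core can move the read-out well past the usual scatter.

The phenyl ring and the carboxylic acid enter together in this one step, so the compounds shown do not tell how much of the drop goes with either part. As far as these compounds go, how a plain phenyl, a primary amide in place of the carboxylic acid, or an ethyl group in place of methyl would read at this position remains open, as does how far compound 3 really lies under the limit.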